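The source may report more compounds than this note shows. Statements on the series, on what has been measured and on what is new or still open speak of the compounds shown alone.

Measured compounds in this series:

compound 1 `NC(=O)c1nn([C@@H]2O[C@H](CO)[C@@H](O)[C@H]2O)nc1C(N)=O`: > 100 uM
compound 2 `NC(=O)c1cn(C2O[C@H](CO)[C@@H](O)[C@H]2O)nc1C(N)=O`: > 100 uM

In a functional assay on L1210 cells (Mus musculus) for inhibition (on this read-out higher numbers stand for weaker inhibition and lower numbers for stronger inhibition), compound 1 returns only a limit, > 100 uM. Compound 2 likewise returns only a limit, > 100 uM. Compound 2 therefore stands exactly where the whole measured set stands: both values shown are limits, and nothing in the numbers separates compound 2 from compound 1 (the limit of > 100 uM in this assay, at which 2 of the 2 values shown sit). Within the data shown here, no step between measured compounds can be sized here, since neither compound gives a number.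

Compound 3 `NC(=O)c1nn(C2O[C@H](CO)[C@@H](O)[C@H]2O)c(N)c1C(N)=O` differs from compound 2 by amino in place of hydrogen on an aromatic carbon, in words amino in place of hydrogen on an aromatic carbon. Nothing measured in this assay shows what such a change does on this core; the two values available are limits only. For the step from compound 2 to compound 3 the expectation is a number no higher from compound 2 to compound 3 (the limit leaves the size open), that is, no step beyond the scatter, with compound 3 most probably also reported as a limit rather than a number. Compound 3 is estimated at 100 uM in this assay, with a range from 30 uM to 300 uM.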

Compound 3, concentration for 50% inhibition: 44 uM
Compound 3: middle estimate off by 2.3-fold (0.36 log units), on the high side; the measured number falls inside the stated range.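

In this assay, among these compounds, amino in place of hydrogen on an aromatic carbon gives an at least 2.2-fold lower number from compound 2 to compound 3 (0.35 log units; beyond the scatter), the first step that can be read. This aromatic carbon, next to the ring nitrogen and next to the ring atom that bears a carbamoyl group, is therefore a place where one substitution on the shared core moves the read-out, and compound 3 is the only compound shown that gives a number rather than a limit. The true size of the step remains unknown because its starting point is a limit rather than a number: the limit of > 100 uM in this assay, at which 2 of the 3 values shown sit.

From the compounds shown here alone, whether the lower number is specific to the amino group or would also follow from another group on this carbon remains open, and a comparison with a methyl, hydroxyl or dimethylamino group at the same place would begin to separate these cases. With a single substitution and a single number on this core, the compounds shown also do not tell how much lower the number could go or whether the trend extends to larger amines.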